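The compounds below may be only part of what the source reports. "The series", "measured", "known", "first", "only" and "open" are said of these compounds alone.

Values in a functional assay on MCF7 cells (Homo sapiens) for cytotoxicity, read by MTT assay, with a stated time of 48 h (a lower number here means a stronger inhibitor, a higher number a weaker inhibitor), so far
- compound 1 `C=C1CC[C@@H]2[C@](C)(CO)[C@H](O)CC[C@@]2(C)[C@@H]1CCc1ccoc1` gives 79500 nM
- compound 2 `C=C1CC[C@@H]2[C@](C)(COC(=O)c3ccc([N+](=O)[O-])cc3)[C@H](O)CC[C@@]2(C)[C@@H]1CCc1ccoc1` gives 62100 nM

For the measured compounds named here, compound 2 stands within the scatter of compound 1 , the only other measured compound. Compound 3 `C=C1CC[C@@H]2[C@](C)(COC(=O)c3ccc([N+](=O)[O-])cc3)[C@H](OC(=O)c3ccc([N+](=O)[O-])cc3)CC[C@@]2(C)[C@@H]1CCc1ccoc1` carries one further change, hydroxy to ((4-nitrophenyl)carbonyl)oxy (4-nitrophenyl)carbonyl in place of hydrogen on an oxygen on a saturated carbon on an oxygen on a saturated carbon whose other neighbours are: saturated ring carbon. Going by the values given here, one measured step bears on this, the same exchange on an oxygen on a saturated carbon, and it gave a 1.3-fold lower number from compound 1 to compound 2 (0.11 log units; within the scatter) without leaving the scatter. No step beyond the scatter is therefore expected in this assay and the expected step is a 1.1-fold lower number from compound 2 to compound 3 (0.05 log units; within the scatter) on present data. The estimated value for compound 3 is 55000 nM with an expected range from 20000 nM to 130000 nM for now.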

Compound 3, half-maximal inhibitory concentration: > 100000 nM
Compound 3 gave a limit, no number; the forecaster's own chance of this, stated with the estimate: 15%; at least 1.8-fold (0.25 log units) between middle value and limit.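

In this assay the (4-nitrophenyl)carbonyl placed on the oxygen on a saturated carbon whose other neighbours are saturated ring carbon gives an at least 1.6-fold higher number from compound 2 to compound 3 (0.20 log units; that floor lies within the scatter). Unlike the same exchange on the first oxygen, this one does not return a number, so the floor fits a step within the scatter or a larger one. For compound 3 the reading is a limit, not a number: the limit of > 100000 nM in this assay, at which 1 of the 3 values shown sits.

As far as these compounds go, it remains open whether a smaller acetyl group on this oxygen, or an amine in place of the nitro group, would give a number in this assay.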